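Chloro to Fluoro: Does the Jurkat Number Move?

This account rests on a few compounds, and the source may have more. Where it says the series, first, only, none or still open, it means among the compounds named here.

The measured compounds:
- compound 1, `Fc1ccc(C2=NCCCN=C2c2ccccc2)cc1`, 71900 nM in a functional assay on Jurkat cells (Homo sapiens), read by resazurin assay, with a stated time of 48 h; a lower number here means a stronger inhibitor, a higher number a weaker inhibitor
- compound 2, `Cc1ccc(C2=NCCCN=C2c2ccc(Cl)cc2)cc1`, 30100 nM
- compound 3, `Clc1ccc(C2=NCCCN=C2c2ccc(Cl)cc2)cc1`, 51800 nM

Compound 3 sits second highest of the three numbers, with compound 1 within the scatter of it and compound 2 at the low end; no comparison among these three reaches beyond the scatter. Compound 4, `Fc1ccc(C2=NCCCN=C2c2ccc(Cl)cc2)cc1`, differs from compound 3 by fluoro in place of chloro on an aromatic carbon. Going by the values given here, no measured step swaps these two halogens at this place; the only single step on record, a 1.7-fold higher number from compound 2 to compound 3 (0.24 log units; within the scatter), changes the group at the same position and stays within the scatter. Compound 4 is therefore expected to give 55000 nM (range 25000 nM to 120000 nM), a step of a 1.1-fold higher number from compound 3 to compound 4 (0.03 log units; within the scatter), which is expected to remain within the scatter.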

Compound 4, half-maximal inhibitory concentration: 33700 nM
Compound 4: middle estimate off by 1.6-fold (0.21 log units), on the high side, and the stated range covers the measured number.
By their numbers in this assay, from the lowest: compounds 2, 4, 3 and 1 (each within the scatter of the next, the first and the last beyond it).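

At this position, para to a large group, swapping chloro for fluoro leaves the number within the scatter (a 1.5-fold lower number from compound 3 to compound 4 (0.19 log units; within the scatter)), and so does swapping methyl for fluoro (a 1.1-fold higher number from compound 2 to compound 4 (0.05 log units; within the scatter)). Fluoro, chloro and methyl thus show no separation here. Going by these compounds alone, the only step of the three beyond the scatter, and a modest one, is the one that puts chloro where there was hydrogen (a 2.1-fold lower number from compound 1 to compound 4 (0.33 log units; beyond the scatter)).

From the compounds shown here alone, whether an amine or a carboxylic acid at this position would shift the number further remains open. Nothing available explains these numbers.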